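Selenium analogue with a tert-butoxycarbonyl-protected glycyl amide

The source may report more compounds than this note shows. Statements on the series, on what has been measured and on what is new or still open speak of the compounds shown alone.

Of the compounds shown here, three built on one shared core have been tested in a functional assay on MCF7 cells (Homo sapiens) for cytotoxicity, read by MTT assay, with a stated time of 24 h; a higher number here means a weaker inhibitor, a lower number a stronger inhibitor. Compound 1, `COc1ccc(N(CC(=O)NCCCSc2ccccc2)C(=O)CCSC2=C(C)C(=O)c3ccccc3C2=O)cc1`, gives 16000 nM. Compound 2, `COc1ccc(N(CC(=O)NCCC[Te]c2ccccc2)C(=O)CNC(=O)OC(C)(C)C)cc1`, gives 5000 nM. Compound 3, `COc1ccc(N(CC(=O)NCCC[Se]c2ccccc2)C(=O)c2ccccc2)cc1`, is reported only at the limit of the assay, >= 100000 nM, not as a number. This is the limit described by the limit of >= 100000 nM in this assay, at which 1 of the 3 values shown sits, and compound 3 is the one of the three that sits there, so its standing on the numbers shown is simply that it is the weakest reading among them.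

Compound 4, `COc1ccc(N(CC(=O)NCCC[Se]c2ccccc2)C(=O)CNC(=O)OC(C)(C)C)cc1`, differs from compound 3 in one place: ((tert-butoxycarbonyl)amino)methyl in place of phenyl on a carbonyl carbon. Among the measured compounds shown here, no step between measured compounds covers this change, so the size of the step is not known from the data. Compound 2 carries the same ((tert-butoxycarbonyl)amino)methyl group and shows 5000 nM, a number rather than a limit. Compound 4 is therefore expected to move from the limit toward a measurable number, by the estimated step of an at least 5.0-fold lower number from compound 3 to compound 4 (0.69 log units; beyond the scatter). The estimate for compound 4 is 20000 nM, within the range 5000 nM to 100000 nM.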

Compound 4, half-maximal inhibitory concentration: >= 100000 nM
Compound 4: no number, only a limit (the forecaster's own chance of this, stated with the estimate: 30%); middle value at least 5.0-fold (0.69 log units) from the limit.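

With the ((tert-butoxycarbonyl)amino)methyl group held in place, selenium in place of tellurium on the saturated chain gives an at least 20-fold higher number from compound 2 to compound 4 (1.30 log units; beyond the scatter) in this assay, the first readable measure of what this exchange is worth. That group on the carbonyl carbon therefore does not by itself bring a selenium compound to a measurable reading. The step from phenyl to that group cannot be read, because compound 3 and compound 4 both stand at a limit of the assay: the limit of >= 100000 nM in this assay, at which 2 of the 4 values shown sit.

What the compounds shown leave open is whether any group on this carbonyl carbon, such as an aminomethyl carrying a free amine or a chain ending in a carboxylic acid, gives a selenium compound a measurable reading. They also leave open how a sulfur atom would compare with selenium and tellurium alongside the ((tert-butoxycarbonyl)amino)methyl group.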